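The source may report more compounds than this note shows. Statements on the series, on what has been measured and on what is new or still open speak of the compounds shown alone.

Measured so far in a functional assay on SNB-75 cells (Homo sapiens) for inhibition, read by sulforhodamine B assay, with a stated time of 48 h, tested at 10 uM; a lower number here means less inhibition, a higher number more inhibition at the concentration tested (going by the name of the read-out):

compound 1, `Brc1cn2ccnc2c(-c2ccc3ncn(C4CCCCC4)c3c2)n1`, 21.3%
compound 2, `c1ccc(-c2cn3ccnc3c(-c3ccc4ncn(C5CCCCC5)c4c3)n2)cc1`, 44.4%
compound 3, `Brc1ccc(-c2cn3ccnc3c(-c3ccc4ncn(C5CCCCC5)c4c3)n2)cc1`, 34.6%

Compound 3 stands second highest of the three numbers. Its nearest neighbour is compound 2, and the two lie within the scatter of each other, as a number 9.8 percentage points lower from compound 2 to compound 3 (within the scatter) shows. Its furthest neighbour is compound 1, from which a number 13.3 percentage points higher from compound 1 to compound 3 (beyond the scatter) separates it, beyond the scatter. The step of a number 23.1 percentage points higher from compound 1 to compound 2 (beyond the scatter), also beyond the scatter, gives the other aryl-for-bromo change in the set.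

Compound 4, `FC(F)(F)c1cccc(-c2cn3ccnc3c(-c3ccc4ncn(C5CCCCC5)c4c3)n2)c1`, has not been measured. It differs from compound 3 as follows: 3-(trifluoromethyl)phenyl in place of 4-bromophenyl on an aromatic carbon. For the measured compounds named here, both measured steps that bear on it concern the same position, and both show that an aryl group there sits above the bromo compound; the only step between two aryl groups, compound 2 to compound 3, stays within the scatter. Going by the values given here, no measured pair shows a trifluoromethyl against a bromo substituent on the pendant ring, so that part of the change is unsupported. The expectation is therefore a step of about a number 3.4 percentage points higher from compound 3 to compound 4 (within the scatter) in this assay, not beyond the scatter in either direction. Compound 4 is estimated at 38%, with a range from 20% to 56%.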

Compound 4, a percentage reported as inhibition, at one concentration (the size of the read-out at that concentration, not a potency): 4.58%
Compound 4: middle estimate off by 33.4 percentage points, on the high side, outside the stated range (below it).
By their numbers in this assay, from the lowest: compound 4; then compound 1; then compounds 3 and 2 (each within the scatter of the next).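

In this assay, an aryl group at this position does not always sit above the bromo compound: a number 16.7 percentage points lower from compound 1 to compound 4 (beyond the scatter) goes against the rise seen for compound 2 and compound 3. The substituent on the pendant ring also matters more than the earlier pair suggested, as a number 39.8 percentage points lower from compound 2 to compound 4 (beyond the scatter) is beyond the scatter, while the step from hydrogen to bromo stayed within it. The change from 4-bromophenyl to 3-(trifluoromethyl)phenyl gives a number 30 percentage points lower from compound 3 to compound 4 (beyond the scatter) and alters both the substituent and where it sits on the pendant ring, so this step alone cannot separate the two.

No information at hand bears on why the number falls with this group. Still open, on these data alone, is whether the fall follows the trifluoromethyl group or its place on the ring, which 4-(trifluoromethyl)phenyl and 3-bromophenyl would separate, and whether an amine or a carboxylic acid on the pendant ring would keep the number of the unsubstituted phenyl compound.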